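Moving the ring nitrogen of a pyridylmethyl amine

The source may report more compounds than this note shows. Statements on the series, on what has been measured and on what is new or still open speak of the compounds shown alone.

Measured so far:
- compound 1 `Cc1ccc(CNC2(CCC(C)(C)C)C(=O)C(C3=NS(=O)(=O)c4cc(NS(C)(=O)=O)ccc4N3)=C(O)c3ccccc32)cn1`: 0.5 h
- compound 2 `CON[C@]1(CCC(C)C)C(=O)C(C2=NS(=O)(=O)c3cc(NS(C)(=O)=O)ccc3N2)=C(O)c2ccccc21`: 0.6 h

Both compounds were tested in an in vivo ADME assay on the whole organism (strain Sprague-Dawley) for metabolic stability, with Rattus norvegicus as the target, at a dose of 5 mg/kg by the intravenous route; on this read-out lower numbers stand for a shorter-lived compound and higher numbers for a longer-lived compound. Compound 1 gives 0.5 h there, and compound 2 gives 0.6 h; the two numbers lie within the usual scatter of each other, so compound 1 cannot be told apart from compound 2 on this read-out. Compound 3 `Cc1cccc(CNC2(CCC(C)(C)C)C(=O)C(C3=NS(=O)(=O)c4cc(NS(C)(=O)=O)ccc4N3)=C(O)c3ccccc32)n1` has not been measured. It differs from compound 1 in one place: 6-methylpyridin-2-yl in place of 6-methylpyridin-3-yl on a saturated chain carbon bound to an amine nitrogen. The atoms are the same and only the position of the ring nitrogen in the pyridine changes. Among the compounds with values here, no measured pair shows what such a shift does in this assay, so there is nothing to build a direction on. The step from compound 1 to compound 3 in this assay is expected to stay within the scatter, that is no change at the digits printed from compound 1 to compound 3 (within the scatter). Compound 3 is therefore estimated at 0.5 h, with a range from 0.25 h to 1 h.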

Compound 3, half-life: 1 h
For compound 3 the middle estimate is 2.0-fold (0.30 log units) below the measured one; low and high end bracket the measured number.
By their numbers in this assay, from the lowest: compounds 1, 2 and 3 (each within the scatter of the next).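

Swapping 6-methylpyridin-3-yl for 6-methylpyridin-2-yl on a saturated chain carbon bound to an amine nitrogen gives the first step that can be read at this position: in this assay there is a 2.0-fold higher number from compound 1 to compound 3 (0.30 log units; within the scatter). Moving the ring nitrogen alone, with the same atoms, therefore produces no difference that can be told from repeat-measurement noise in this read-out, while compound 2 differs from the others in more than one place and cannot be compared with them. No measurement given here explains the size of this step.

Going by these compounds, it remains open whether a plain phenyl ring in place of the pyridine would also stay within the scatter. The same is true of a pyridine that lacks the methyl group, or one that carries a carboxylic acid in its place.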